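Opening the Ring Amine on a Shared Core

This account rests on a few compounds, and the source may have more. Where it says the series, first, only, none or still open, it means among the compounds named here.

Within the data shown here, compound 3 `CN1CCCCC(n2nc(Cc3ccc(Cl)cc3)c3ccccc3c2=O)C1` is one of three compounds measured in an assay for binding affinity to Alpha-1B adrenergic receptor (Homo sapiens) (on this read-out higher numbers stand for weaker inhibition and lower numbers for stronger inhibition), where compound 3 gives 158 nM. Compound 1 `CN1CCC(Cn2nc(Cc3ccc(Cl)cc3)c3ccccc3c2=O)C1` gives 79.4 nM, and compound 2 `CN1CCC[C@@H]1Cn1nc(CCc2ccccc2)c2ccccc2c1=O` gives 200 nM; compound 3 holds the second highest of these three numbers, and all three lie within the scatter of one another. Compound 4 `CN(C)CCCn1nc(Cc2ccc(Cl)cc2)c2ccccc2c1=O` differs from compound 3 in one place: 3-(dimethylamino)propyl in place of 1-methylazepan-3-yl on an aromatic nitrogen. Because a 2.0-fold higher number from compound 1 to compound 3 (0.30 log units; within the scatter) also swapped the group on this aromatic nitrogen and stayed within the scatter, compound 4 is expected to sit close to compound 3, with a 1.0-fold higher number from compound 3 to compound 4 (0.01 log units; within the scatter) as the expected step. The estimate for compound 4 in this assay is 160 nM, in a range from 50 nM to 500 nM.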

Compound 4, inhibition constant: 316 nM
The estimate for compound 4 lay 2.0-fold (0.30 log units) below the measured number; the measured number falls inside the stated range.
By their numbers in this assay, from the lowest: compounds 1, 3, 2 and 4 (each within the scatter of the next, the first and the last beyond it).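

In this assay the open chain 3-(dimethylamino)propyl gives a 2.0-fold higher number from compound 3 to compound 4 (0.30 log units; within the scatter) and so, on this aromatic nitrogen, swapping the seven-membered ring for the chain cannot be told apart from the scatter. Against the (1-methylpyrrolidin-3-yl)methyl group, however, the same open chain gives a 4.0-fold higher number from compound 1 to compound 4 (0.60 log units; beyond the scatter) and this is the first step here to pass beyond the scatter, showing that the group at this position can measurably change the number.

As far as these compounds go, what a longer chain, or a primary amine in place of the dimethylamino group, would do at this position stays open. No measurement at hand gives a reason for these steps.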